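A Pyridin-4-yl in Place of a 4-Hydroxyphenyl

The source may hold more compounds than are shown below. What is called first, only, known or untested is meant among the compounds shown, and "the series" means these compounds.

Three compounds built on one shared core have been examined in a functional assay on CHO cells for agonist activity at Alpha-2C adrenergic receptor (Homo sapiens); a higher number here means a larger maximal response, a lower number a smaller maximal response. Compound 1 `CC(Oc1ccccc1-c1ccccc1[N+](=O)[O-])C1=NCCN1` gives < 0.3 in this assay, which is a limit of the assay and not a number. Compound 2 `CC(Oc1ccccc1-c1ccccc1)C1=NCCO1` likewise reaches only the limit < 0.3 in this assay. Compound 3 `CC(Oc1ccccc1-c1ccc(O)cc1)C1=NCCN1` stands at < 0.3 in this assay, again a limit rather than a measured value. No pair among these three differs in one place only, so no measured step can be drawn from them; what they have in common is the limit of < 0.3 in this assay, at which 3 of the 3 values shown sit, and none of the three rises above it.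

Compound 4 `CC(Oc1ccccc1-c1ccncc1)C1=NCCN1` is the next compound to be tested in this assay, and it departs from compound 3 by a single exchange: pyridin-4-yl in place of 4-hydroxyphenyl on an aromatic carbon. For the measured compounds named here, since the three measured compounds all sit at the limit, there is no step on record to lean on. The expected step that the limit leaves unreadable from compound 3 to compound 4 is none beyond the usual scatter, and compound 4 is expected to remain low, with an estimate of 0.2 and a range from 0.05 to 0.45, most likely reported again as a limit.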

Compound 4, intrinsic activity: the largest response reached, as a fraction of the reference agonist's: < 0.3
Compound 4: only a limit was reported; the forecaster's own chance of this, stated with the estimate: 70%; the middle value does not contradict the limit.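

Compound 3 and compound 4 are both reported only as limits in this assay and so no step can be read between them, whatever the exchange of 4-hydroxyphenyl for pyridin-4-yl may do. All the compounds shown share one limit: the limit of < 0.3 in this assay, at which 4 of the 4 values shown sit. They leave open how large a maximal response any compound on this shared core can reach.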